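Swapping chloro for fluoro on the sulfonamide aryl ring

This account rests on a few compounds, and the source may have more. Where it says the series, first, only, none or still open, it means among the compounds named here.

Compound 1 `Cc1ccccc1C(=O)NCc1ccc(CNS(=O)(=O)c2cccc(Cl)c2)cc1` was characterised in an assay on MDA-MB-231 cells for displacement of a labelled ligand from C-X-C chemokine receptor type 4 (Homo sapiens), read by fluorescence and microscopy, with stated times of 10 min and 30 min (on this read-out higher numbers stand for an effect only at larger amounts of compound and lower numbers for an effect already at smaller amounts), and gave 100 nM. Compound 2 `COc1ccccc1C(=O)NCc1ccc(CNS(=O)(=O)c2ccccc2Cl)cc1` gave 100 nM in this assay, level with compound 1 within the usual scatter, so the two share the lowest value among the three measured compounds. Compound 3 `O=C(NCc1ccc(CNS(=O)(=O)c2ccc(Cl)cc2)cc1)c1cccnc1` gave 1000 nM in this assay, a higher number that lies beyond the scatter. Compound 4 `Cc1ccccc1C(=O)NCc1ccc(CNS(=O)(=O)c2cccc(F)c2)cc1` has not been measured; its difference from compound 1 is fluoro in place of chloro on an aromatic carbon. For the measured compounds named here, with no measured pair showing this change, the expected step of a 2.5-fold higher number from compound 1 to compound 4 (0.40 log units; beyond the scatter) is a modest rise in the number, around the edge of the scatter. Compound 4 is estimated to give 250 nM in this assay, within 100 nM to 800 nM.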

Compound 4, effective concentration (reported as EC, without a stated level of effect): 100 nM
Estimate against measurement, compound 4: 2.5-fold (0.40 log units) above; low and high end bracket the measured number.
By their numbers in this assay, from the lowest: compounds 1, 2 and 4 (each within the scatter of the next); then compound 3.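

In this assay, the change from 3-chlorophenyl to 3-fluorophenyl gives no change at the digits printed from compound 1 to compound 4 (within the scatter) and so shows that, on this aromatic carbon of the sulfonamide ring, fluoro can stand in place of chloro without a step beyond the scatter. For the compounds shown here, this is the first comparison here of compounds that differ in one place, and it rests on this single pair. Nothing available accounts for this result.

On these data alone, it remains open whether bromo, a nitrile or an amine on this carbon would also leave the number level. As far as these compounds go, whether the same swap reads alike with a different amide part also remains open.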